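The source may report more compounds than this note shows. Statements on the series, on what has been measured and on what is new or still open speak of the compounds shown alone.

Measured so far:
compound 1 `CCC[C@H]1O[C@H](COCc2ccccc2)[C@H](OCc2ccccc2)[C@H](OCc2ccccc2)[C@H]1O`: "not active" (no number reported)
compound 2 `O[C@H]1CO[C@H](COCc2ccccc2)[C@@H](OCc2ccccc2)[C@@H]1OCc1ccccc1`: "not active" (no number reported)
compound 3 `CCC[C@H]1O[C@H](COCc2ccccc2)[C@@H](OCc2ccccc2)[C@H](OCc2ccccc2)[C@H]1O`: 28200 nM

Going by the values given here, in a functional assay on HL-60 cells (Homo sapiens) for antiproliferative activity, read by MTT assay (on this read-out lower numbers stand for stronger inhibition and higher numbers for weaker inhibition), compound 3 gives 28200 nM, the only number recorded in this small set, and by that number it sits at the weak end of what this read-out resolves. Among the compounds with values here, compound 1 in this assay returns "not active" (no number reported), and compound 2 in this assay returns "not active" (no number reported); neither entry carries a number, so no step between measured compounds can be quantified. the fact that compounds 1 and 3 differ only in the configuration as drawn is worth noting as the one structural relation among the measured entries, but without a number for compound 1 it yields no step size.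

Compound 4 `O[C@@H]1[C@@H](OCc2ccccc2)[C@H](OCc2ccccc2)[C@@H](COCc2ccccc2)O[C@@H]1c1ccccc1` is the next entry to be run. phenyl in place of propyl on a saturated ring carbon The change is confined to the substituent on that saturated ring carbon; the shared core and the three benzyloxy-type groups are untouched. Within the data shown here, with no measured step to calibrate such a change, the expectation rests on compound 3 alone. No shift beyond the usual scatter is expected, so the step of a 1.1-fold higher number from compound 3 to compound 4 (0.03 log units; within the scatter) is an estimate of essentially no change. Compound 4 is expected to give about 30000 nM in this assay, within 8000 nM to 100000 nM, with a real chance that the read-out again reports only a limit, as it did for compound 1 and compound 2.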

Compound 4, half-maximal inhibitory concentration: "not active" (no number reported)
For compound 4 the study gives words and no number; there is nothing to compare the estimate with.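

In this assay, going by these compounds alone, compound 4 gives "not active" (no number reported) and compound 3 gives 28200 nM, so no step between the two can be read. Left open is what phenyl in place of propyl does to the read-out, and what configuration alone does, where the only structural relation noted so far offers no step size: the fact that compounds 1 and 3 differ only in the configuration as drawn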